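Swapping a Naphthyl Ring for Fluorophenyl: Expected Cytotoxicity

The source may hold more compounds than are shown below. What is called first, only, known or untested is meant among the compounds shown, and "the series" means these compounds.

Compound 1: `Cc1cc(C#N)cc(C)c1Oc1nc(Nc2ccc(C#N)cc2)ncc1-c1cccc2ccccc12`, > 267000 nM
Compound 2: `Cc1cc(C#N)cc(C)c1Oc1nc(Nc2ccc(C#N)cc2)ncc1-c1ccc2ccccc2c1`, 8460 nM

Compound 1 `Cc1cc(C#N)cc(C)c1Oc1nc(Nc2ccc(C#N)cc2)ncc1-c1cccc2ccccc12` gives > 267000 nM in an ADME assay on MT4 cells (Homo sapiens) for cytotoxicity, read by MTT assay, with a stated time of 5 days (a lower number here means that less compound is tolerated, a higher number that more compound is tolerated), and this value is a limit of the assay rather than a number (the limit of > 267000 nM in this assay, at which 1 of the 2 values shown sits). Compound 2 `Cc1cc(C#N)cc(C)c1Oc1nc(Nc2ccc(C#N)cc2)ncc1-c1ccc2ccccc2c1` gives 8460 nM; the step of an at least 31-fold lower number from compound 1 to compound 2 (1.49 log units; beyond the scatter) is large, and compound 2 therefore stands as the only true number shown. Compound 3 `Cc1cc(C#N)cc(C)c1Oc1nc(Nc2ccc(C#N)cc2)ncc1-c1ccc(F)cc1` differs from compound 2 by 4-fluorophenyl in place of naphthalen-2-yl on an aromatic carbon. For the measured compounds named here, no measured step covers this change; the single known step compares two naphthyl isomers only and sets no direction here. Compound 3 is expected to give 30000 nM, between 8000 nM and 150000 nM, an expected step of a 3.5-fold higher number from compound 2 to compound 3 (0.55 log units; beyond the scatter).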

Compound 3, half-maximal cytotoxic concentration: 42700 nM
Compound 3: middle estimate off by 1.4-fold (0.15 log units), on the low side; measured number inside the range.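

In this assay, putting 4-fluorophenyl on this aromatic carbon gives a 5.0-fold higher number from compound 2 to compound 3 (0.70 log units; beyond the scatter), and against the other naphthyl isomer it gives an at least 6.2-fold lower number from compound 1 to compound 3 (0.79 log units; beyond the scatter). A group with one aromatic ring instead of two therefore lands apart from both naphthyl compounds, so this position responds to more than the difference between the two naphthyl isomers. The value of compound 1 is a limit of the assay, not a number: the limit of > 267000 nM in this assay, at which 1 of the 3 values shown sits.

The compounds shown cannot separate the effect of the fluorine from that of losing the second ring. Plain phenyl, or a phenyl ring carrying an amine, would help to tell these apart.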